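An Amino Group Added on Two Related Benzyl Cores

The source may report more compounds than this note shows. Statements on the series, on what has been measured and on what is new or still open speak of the compounds shown alone.

The set holds three measured compounds and one that awaits measurement. Compound 1 has the structure `ClCc1ccc(Cn2cnc3c(Cl)ncnc32)cc1` and compound 2 the structure `Nc1nc(Cl)c2ncn(Cc3ccc(CCl)cc3)c2n1`; the two are cousins, compound 2 carrying an amino group where compound 1 carries hydrogen. In a functional assay on BT-549 cells (Homo sapiens) for cytotoxicity, read by sulforhodamine B assay, with a stated time of 48 h (on this read-out lower numbers stand for stronger inhibition of growth and higher numbers for weaker inhibition of growth), compound 1 gives 5620 nM, and compound 2 gives 6920 nM. The change between them, (amino in place of hydrogen on an aromatic carbon), produced a 1.2-fold higher number from compound 1 to compound 2 (0.09 log units; within the scatter), so the amino group left the read-out essentially where it was.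

Compound 3, with the structure `ClCc1ccccc1Cn1cnc2c(Cl)ncnc21`, is built from the same atoms as compound 1 joined differently; the difference between the two cores is not broken down here. In this assay compound 3 gives 1990 nM, the lowest of the three numbers, with both compound 1 and compound 2 standing beyond the scatter above it.

Compound 4, whose structure is `Nc1nc(Cl)c2ncn(Cc3ccccc3CCl)c2n1`, stands to compound 3 as compound 2 stands to compound 1: the change is amino in place of hydrogen on an aromatic carbon, the same change as before, at the same place. For the measured compounds named here, because the earlier step was a 1.2-fold higher number from compound 1 to compound 2 (0.09 log units; within the scatter), the account expects the step from compound 3 to compound 4 in this assay to be similarly small, about a 1.2-fold higher number from compound 3 to compound 4 (0.08 log units; within the scatter), the one precedent being the only basis. Compound 4 is therefore estimated to give 2400 nM, within a range of 1200 nM to 5000 nM.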

Compound 4, concentration for 50% growth inhibition: 8130 nM
Beside the measured number, compound 4's estimate is 3.4-fold (0.53 log units) below it; the whole stated range lies below it.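

In this assay, amino in place of hydrogen on an aromatic carbon gave a 4.1-fold higher number from compound 3 to compound 4 (0.61 log units; beyond the scatter), while the same change at the same place on the other core gave a 1.2-fold higher number from compound 1 to compound 2 (0.09 log units; within the scatter). The size of the step therefore did not carry over from one core to the other, and a step that left the read-out essentially unchanged on one core was no guide to the other: the same change on two cores in this assay, a 1.2-fold higher number (0.09 log units; within the scatter) from compound 1 to compound 2 and a 4.1-fold higher number (0.61 log units; beyond the scatter) from compound 3 to compound 4, 3.3-fold (0.52 log units) apart, beyond the scatter of two such steps. This shows that, for these two pairs, the result of adding the amino group depends on the core that carries it, but it does not show why the cores differ, and two pairs set no rule for any further core in the series.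

The compounds shown leave open whether other groups on that aromatic carbon between two ring nitrogen atoms, such as a methylamino group, a dimethylamino group or a hydroxyl, would follow the amino group on each core. They also leave open whether the chloro group on the same ring, if exchanged for a methoxy group or a fluoro group, would alter the gap between the two steps.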